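A Bromine-for-Chlorine Swap on a Shared Indole-Free Core

This account rests on a few compounds, and the source may have more. Where it says the series, first, only, none or still open, it means among the compounds named here.

Of the compounds shown here, three built on one shared core have been tested for their effect on the growth of lung-derived cancer cells. The measure is a functional assay on A549 cells (Homo sapiens) for inhibition, read by MTT assay, with a stated time of 72 h; a lower number here means a stronger inhibitor of growth, a higher number a weaker inhibitor of growth. Compound 1, with the structure `Clc1ccc(Sc2c(-c3ccc(Br)cc3)[nH]c3ccccc23)cc1`, gives 26000 nM. Compound 2, with the structure `O=C(COc1ccc(Cl)cc1)Nc1c(-c2ccccc2)[nH]c2ccccc12`, gives 37000 nM. Compound 3, with the structure `CCN(CC)C(=S)Sc1c(-c2ccccc2)[nH]c2ccc(Br)cc12`, gives 31000 nM. Compound 1 sits alongside the other two: all three numbers lie within the usual scatter of repeated measurements of one another, so none of them stands apart, and all three are weak growth inhibitors.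

Compound 4, with the structure `Clc1ccc(Sc2c(-c3ccc(Cl)cc3)[nH]c3ccccc23)cc1`, has not yet been measured. It differs from compound 1 in a single place: chloro in place of bromo on an aromatic carbon. Within the data shown here, nothing among the measured compounds shows what this particular exchange does in this assay, since no two of them differ only in this way. Bromo and chloro are both single halogen atoms of similar size, so the step from compound 1 to compound 4 is expected to be small, with no clear direction and most likely within the scatter, as a 1.1-fold higher number from compound 1 to compound 4 (0.03 log units; within the scatter). On that basis compound 4 is estimated to give 28000 nM, with a plausible range from 12000 nM to 65000 nM.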

Compound 4, concentration for 50% growth inhibition: 27000 nM
Estimate against measurement, compound 4: 1.0-fold (0.02 log units) above; the measured number falls inside the stated range.
By their numbers in this assay, from the lowest: compounds 1, 4, 3 and 2 (each within the scatter of the next).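

Among these compounds, exchanging 4-bromophenyl for 4-chlorophenyl gives a 1.0-fold higher number from compound 1 to compound 4 (0.02 log units; within the scatter) in this assay, and this is the first comparison that changes just one place, which the earlier compounds could not offer. At this position, on an aromatic carbon para to a large group, bromo and chloro therefore cannot be told apart in this assay, and growth inhibition stays weak with either halogen. No separate measurement is available that could explain why the two compounds read alike.

A single pair of halogens cannot show whether this position matters to growth inhibition at all, and a group of a quite different kind, such as an amine, a carboxylic acid or a longer alkyl chain, would test that far more sharply. As far as these compounds go, it also remains open whether a change at this position would have the same small effect on a different core, such as that of compound 2 or compound 3, where the group attached to the shared ring system is not the same.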